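One Stereocentre Inverted in a Cytotoxic Series

This account rests on a few compounds, and the source may have more. Where it says the series, first, only, none or still open, it means among the compounds named here.

Values in a functional assay on MCF7 cells (Homo sapiens) for cytotoxicity, read by sulforhodamine B assay, with a stated time of 3 days (on this read-out higher numbers stand for weaker inhibition and lower numbers for stronger inhibition), are:
Compound 1 `Cc1cn(C2CN(S(=O)(=O)c3ccccc3[N+](=O)[O-])c3ccccc3CO2)c(=O)[nH]c1=O` gives 45200 nM
Compound 2 `Nc1ccccc1S(=O)(=O)N1CC(n2cnc3c(Cl)nc(Cl)nc32)OCc2ccccc21` gives 820 nM
Compound 3 `O=[N+]([O-])c1ccc(S(=O)(=O)N2C[C@H](n3cnc4c(Cl)nc(Cl)nc43)OCc3ccccc32)cc1` gives 190 nM

Of these three, compound 3 has the lowest number and so shows the strongest inhibition in this assay. It stands clear of the scatter on both sides, with compound 2 the nearest and compound 1 by far the furthest. Compound 4 `O=[N+]([O-])c1ccc(S(=O)(=O)N2C[C@@H](n3cnc4c(Cl)nc(Cl)nc43)OCc3ccccc32)cc1` has not yet been measured. Its relation to compound 3 is simple: the two compounds have the same atoms and bonds and differ only in configuration as drawn: 1 of 1 stereo elements differ; a stereocentre at a saturated ring carbon is drawn R in compound 3 and S in compound 4. Nothing leaves and nothing enters, and the stereocentre at a saturated ring carbon, drawn R in compound 3, is drawn S in compound 4. Within the data shown here, no measured pair here differs in configuration alone, so the data do not show what such an inversion does. The expectation therefore rests on compound 3 (190 nM) as the sole close reference. The expected change is a 1.4-fold higher number from compound 3 to compound 4 (0.14 log units; within the scatter) and so leans slightly toward weaker inhibition, most likely without passing beyond the usual scatter. For compound 4 the estimated value is 260 nM, with an expected range of 90 nM to 800 nM.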

Compound 4, half-maximal inhibitory concentration: 100 nM
Compound 4: the middle estimate sits 2.6-fold (0.41 log units) above what was measured, within the range that was stated.
By their numbers in this assay, from the lowest: compounds 4 and 3 (each within the scatter of the next); then compound 2; then compound 1.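

In this assay, among these compounds, the inversion gives a 1.9-fold lower number from compound 3 to compound 4 (0.28 log units; within the scatter), the first reading of what configuration alone does at this saturated ring carbon. Activity in this pair therefore does not depend on one drawn configuration at this position, since going from R to S leaves the two values within the scatter of each other. The pair reads as a test of this stereocentre alone, with no other structural change to weigh: the fact that compounds 3 and 4 differ only in the configuration as drawn.

As far as these compounds go, it remains open whether the two configurations would stay this close with a carboxylic acid or an amine in place of the nitro group. From the compounds shown here alone, it is also open whether they would do so in compound 1 and compound 2, both drawn without a defined configuration at this carbon.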